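A few compounds are considered here, and "the series" means these few. Any claim that something is new, unique, unknown or untested is made for them only; others in the source may bear on it.

Measured compounds:
compound 1 `Cc1c(OCCCCOc2ccc(Cl)c(C(=O)O)c2)ccc(C(=O)CC(C)(C)C)c1O` – 87 nM
compound 2 `CNC(=O)c1cc(OCCCCOc2ccc(C(=O)CC(C)(C)C)c(O)c2C)ccc1F` – 164 nM
compound 3 `COc1cc(OCCCCOc2ccc(C(=O)CC(C)(C)C)c(O)c2C)cc(C(=O)O)c1` – 102 nM

In an assay for positive allosteric modulation of metabotropic glutamate receptor 2 (Rattus norvegicus) (on this read-out lower numbers stand for an effect already at smaller amounts and higher numbers for an effect only at larger amounts of compound), compound 1 gives 87 nM, the lowest of the three numbers. Compound 3 gives 102 nM and compound 2 gives 164 nM; both lie within the usual scatter of compound 1, so the three cannot be ranked. Compound 4 `Cc1c(OCCCCOc2ccc(C(=O)O)cc2F)ccc(C(=O)CC(C)(C)C)c1O` is not yet measured. It differs from compound 1 in one place: 4-carboxy-2-fluorophenyl in place of 3-carboxy-4-chlorophenyl on an oxygen on a saturated carbon. Among the compounds with values here, the leaving and entering groups match in what is counted, and no step between measured compounds that differ in one place is known. A step of no more than the scatter is therefore expected, a 1.3-fold higher number from compound 1 to compound 4 (0.10 log units; within the scatter), in no preferred direction. Compound 4 is estimated at 110 nM, with a range from 45 nM to 270 nM.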

Compound 4, half-maximal effective concentration: 75 nM
Compound 4: the middle estimate sits 1.5-fold (0.17 log units) above what was measured; measured number inside the range.
By their numbers in this assay, from the lowest: compounds 4, 1, 3 and 2 (each within the scatter of the next, the first and the last beyond it).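

In this assay the step is a 1.2-fold lower number from compound 1 to compound 4 (0.06 log units; within the scatter) for 4-carboxy-2-fluorophenyl in place of 3-carboxy-4-chlorophenyl on an oxygen on a saturated carbon. So this place accepts fluorine instead of chlorine, with the carboxylic acid and the halogen arranged differently on the ring, and the difference stays within the usual scatter. Nothing on hand explains this result. From the compounds shown here alone, what stays open is how a tetrazole in place of the carboxylic acid, or a pyridine in place of the benzene ring, would read at this place.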